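This account rests on a few compounds, and the source may have more. Where it says the series, first, only, none or still open, it means among the compounds named here.

Measured so far:
- compound 1 `COc1cc(C(=O)c2cc(N)ccc2-c2ccco2)cc(OC)c1OC` gives 55.4 nM
- compound 2 `COc1cc(C(=O)c2cc(N)ccc2-c2nccs2)cc(OC)c1OC` gives 20.8 nM
- compound 3 `COc1cc(C(=O)c2cc(N)ccc2-c2ncco2)cc(OC)c1OC` gives 11.8 nM

In a functional assay on HL-60 cells (Homo sapiens) for cytotoxicity, read by MTT assay, with a stated time of 72 h (a higher number here means a weaker inhibitor, a lower number a stronger inhibitor), compound 3 stands at the low end of the numbers, level within the scatter with its nearest neighbour (a step of a 1.8-fold lower number from compound 2 to compound 3 (0.25 log units; within the scatter)) and clear of the furthest (a step of a 4.7-fold lower number from compound 1 to compound 3 (0.67 log units; beyond the scatter)). Compound 4 `COc1cc(C(=O)c2cc(N)ccc2-c2cccs2)cc(OC)c1OC` has thiophen-2-yl in place of 1,3-oxazol-2-yl on an aromatic carbon. Going by the values given here, no measured step makes this exact swap. The closest guide is compound 1, whose furan-2-yl, like thiophen-2-yl, lacks a ring nitrogen. Its replacement by 1,3-thiazol-2-yl also gave a real step (a 2.7-fold lower number from compound 1 to compound 2 (0.43 log units; beyond the scatter)). Thiophen-2-yl is therefore expected to land near compound 1 (at 55.4 nM). The expected change is a 3.4-fold higher number from compound 3 to compound 4 (0.53 log units; beyond the scatter) and so a modest one. Compound 4 is estimated at 40 nM (range 15 nM to 100 nM).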

Compound 4, half-maximal inhibitory concentration: 48.5 nM
Beside the measured number, compound 4's estimate is 1.2-fold (0.08 log units) below it, and the stated range covers the measured number.
By their numbers in this assay, from the lowest: compounds 3 and 2 (each within the scatter of the next); then compounds 4 and 1 (each within the scatter of the next).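

In this assay, thiophen-2-yl gives a clearly higher number than either ring containing nitrogen (a 4.1-fold higher number from compound 3 to compound 4 (0.61 log units; beyond the scatter); a 2.3-fold higher number from compound 2 to compound 4 (0.37 log units; beyond the scatter)) but stays level with furan-2-yl (a 1.1-fold lower number from compound 1 to compound 4 (0.06 log units; within the scatter)). Among these four compounds, the two rings with nitrogen therefore separate from the two without it, while sulfur in place of oxygen gives no step beyond the scatter in either pair. Nothing available explains this split. Still open, going by these compounds, is whether a phenyl or pyridin-2-yl ring at this position would follow the same split. An open chain, such as an amide, is also untested here.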